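The source may report more compounds than this note shows. Statements on the series, on what has been measured and on what is new or still open speak of the compounds shown alone.

Of the compounds shown here, two sharing one core have been tested. Compound 1 `CCc1ccc(N2C(=O)NC3(CSC4=C3C(=O)c3ncccc3C4=O)C2=O)cc1` gives in a functional assay on MT4 cells (Homo sapiens) for antiproliferative activity, read by MTT assay, with a stated time of 96 h (a lower number here means a stronger inhibitor, a higher number a weaker inhibitor), a value of 1 nM. Compound 2 `O=C1NN(c2ccc([N+](=O)[O-])cc2)C(=O)C2(CSC3=C2C(=O)c2ncccc2C3=O)N1` gives in this assay a value of 5 nM, the higher of the two numbers, a gap that lies beyond the usual scatter of repeated measurements. Compound 3 `O=C1NN(c2ccccc2)C(=O)C2(CSC3=C2C(=O)c2ncccc2C3=O)N1` is not yet measured; it differs from compound 2 in one place: hydrogen in place of nitro on an aromatic carbon. No comparable change has been measured here, so the size of the step is open. The step from compound 2 to compound 3 is expected to be small, a 1.6-fold higher number from compound 2 to compound 3 (0.20 log units; within the scatter), none beyond the scatter. Compound 3 is therefore estimated at 8 nM, within a range from 2 nM to 30 nM.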

Compound 3, half-maximal inhibitory concentration: 150 nM
Estimate against measurement, compound 3: 19-fold (1.27 log units) below; the measured number lies above the stated range.
By their numbers in this assay, from the lowest: compound 1; then compound 2; then compound 3.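

In this assay the change from 4-nitrophenyl to phenyl brings a 30-fold higher number from compound 2 to compound 3 (1.48 log units; beyond the scatter) and so gives the first measured sign that the group on this aromatic carbon, para to a large group, matters greatly. A bare hydrogen there is clearly not equal to nitro. Nothing available explains the size of this loss. On these data alone, whether nitro itself is needed remains open, since an amine, a methoxy group or a carboxylic acid at this place could behave quite differently. The compounds shown also leave open how a longer chain there would compare.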